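Ester in Place of Amide on the Shared Core

The compounds below may be only part of what the source reports. "The series", "measured", "known", "first", "only" and "open" are said of these compounds alone.

Compound 2 `CCNC(=O)C1=Cc2ccc(OC)cc2OC1c1cc(OC)c(OC)c(OC)c1`, in a functional assay for inhibition of nuclear factor NF-kappa-B complex (Homo sapiens) (on this read-out lower numbers stand for stronger inhibition and higher numbers for weaker inhibition), gives only a limit, > 50000 nM. Compound 3 `COc1ccc2c(c1)OC(c1cc(OC)c(OC)c(OC)c1)C(C(=O)NC(C)C)=C2` likewise stands at a limit in this assay, > 50000 nM. Compound 1 `COc1ccc2c(c1)OC(c1cc(OC)c(OC)c(OC)c1)C(C(=O)OC(C)(C)C)=C2`, carrying tert-butoxy on the carbonyl carbon, gives 14100 nM in this assay. Because the amide values sit at the limit of > 50000 nM in this assay, at which 2 of the 3 values shown sit, the steps of an at least 3.5-fold higher number from compound 1 to compound 2 (0.54 log units; beyond the scatter) and an at least 3.5-fold higher number from compound 1 to compound 3 (0.54 log units; beyond the scatter) read as at least modest losses on moving from ester to amide. Compound 4 `COC(=O)C1=Cc2ccc(OC)cc2OC1c1cc(OC)c(OC)c(OC)c1` reverses that direction: methoxy in place of ethylamino on a carbonyl carbon. A returning ester is expected to recover some ground, though compound 1 shows the ester series itself is weak. Compound 4 is therefore estimated at 20000 nM, between 7000 nM and 60000 nM. The expected step is an at least 2.5-fold lower number from compound 2 to compound 4 (0.39 log units; beyond the scatter).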

Compound 4, half-maximal inhibitory concentration: 13800 nM
Estimate against measurement, compound 4: 1.4-fold (0.16 log units) above; measured number inside the range.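

Methoxy in place of ethylamino gives an at least 3.6-fold lower number from compound 2 to compound 4 (0.55 log units; beyond the scatter), and methoxy in place of isopropylamino gives an at least 3.6-fold lower number from compound 3 to compound 4 (0.55 log units; beyond the scatter), so the advantage of ester over amide on this carbonyl carbon is not confined to tert-butoxy. Between the two esters the step is a 1.0-fold lower number from compound 1 to compound 4 (0.01 log units; within the scatter), so methyl and tert-butyl on the oxygen cannot be told apart in this assay. Compound 2 and compound 3 both stand at a limit, so the steps to compound 4 give only a minimum size: the limit of > 50000 nM in this assay, at which 2 of the 4 values shown sit.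

On these data alone, whether a carboxylic acid on this carbonyl carbon would read like the esters or like the amides stays open. So does the effect of a longer chain or a benzyl group on the ester oxygen.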